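The compounds below may be only part of what the source reports. "The series", "measured", "known", "first", "only" and "open" are said of these compounds alone.

Three compounds share one core and differ only in the group attached to the carbonyl carbon. Compound 1 `COc1ccc(C(=O)N/N=C(C)/C=N/Nc2ccc([N+](=O)[O-])cc2)cc1` carries a 4-methoxyphenyl there, compound 2 `CC(/C=N/Nc1ccc([N+](=O)[O-])cc1)=N\NC(=O)c1ccccc1C` a 2-methylphenyl, and compound 3 `CC(/C=N/Nc1ccc([N+](=O)[O-])cc1)=N\NC(=O)c1ccccc1F` a 2-fluorophenyl. In an ADME assay on J774 cells (Mus musculus, strain BALB/c) for cytotoxicity, read by resazurin assay, with a stated time of 72 h (a lower number here means that less compound is tolerated, a higher number that more compound is tolerated), compound 1 gives only a limit of the assay, > 100000 nM. In this assay compound 2 likewise gives a limit, > 100000 nM. In this assay compound 3 also stands at a limit, > 100000 nM. All three therefore sit at the limit of > 100000 nM in this assay, at which 3 of the 3 values shown sit, and so the step that the two limits leave unreadable from compound 1 to compound 2, the step that the two limits leave unreadable from compound 1 to compound 3 and the step that the two limits leave unreadable from compound 2 to compound 3 cannot be read as numbers.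

Compound 4 `CC(/C=N/Nc1ccc([N+](=O)[O-])cc1)=N\NC(=O)c1ccc(N(C)C)cc1` continues the same kind of exchange: 4-(dimethylamino)phenyl in place of 2-fluorophenyl on a carbonyl carbon. Each of the three measured steps bears on this change, since each also swaps the group on the carbonyl carbon, and each left its compound at the limit of > 100000 nM in this assay, at which 3 of the 3 values shown sit. For compound 4 no step beyond the scatter is expected, a step that the limit leaves unreadable from compound 3 to compound 4, because compound 3 and its neighbours all rest at the limit of > 100000 nM in this assay, at which 3 of the 3 values shown sit. For compound 4 the estimate in this assay is 150000 nM, with an expected range from 60000 nM to 400000 nM, and most likely the result will again be only a limit.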

Compound 4, half-maximal cytotoxic concentration: > 100000 nM
Compound 4 was reported as a limit; the forecaster's own chance of this, stated with the estimate: 85%; the middle value is on the limit's open side.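

In this assay compound 4 at > 100000 nM again gives only a limit of the assay, so its steps from compound 1, compound 2 and compound 3 cannot be read as numbers: the limit of > 100000 nM in this assay, at which 4 of the 4 values shown sit. As far as these compounds go, how far past that limit each of these four compounds lies, and whether the groups on the carbonyl carbon differ at all, remains open.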